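This account rests on a few compounds, and the source may have more. Where it says the series, first, only, none or still open, it means among the compounds named here.

Measured so far:
- compound 1 `COc1ccc(N2CCN(C3=CC(=O)c4ccccc4C3=O)CC2)cc1`: 46100 nM
- compound 2 `O=C1C=C(N2CCN(c3cccc(Cl)c3)CC2)C(=O)c2ccccc21`: 8300 nM

In a functional assay on DU-145 cells (Homo sapiens) for inhibition, read by MTT assay, with a stated time of 72 h (a lower number here means a stronger inhibitor, a higher number a weaker inhibitor), compound 2 gives 8300 nM, the lower of the two numbers, which makes it the stronger inhibitor of this pair. For the measured compounds named here, the only measured step is a 5.6-fold lower number from compound 1 to compound 2 (0.74 log units; beyond the scatter). It came from putting 3-chlorophenyl in place of 4-methoxyphenyl on an amine nitrogen in a ring, and it lies beyond the scatter.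

The next compound is compound 3 `O=C1C=C(N2CCN(c3ccccc3Cl)CC2)C(=O)c2ccccc21`. It has the same atoms as compound 2, joined differently, with 2-chlorophenyl in place of 3-chlorophenyl on that same nitrogen: 2-chlorophenyl in place of 3-chlorophenyl on an amine nitrogen in a ring.

Going by the values given here, no measured step shows what this kind of change does. The step of a 5.6-fold lower number from compound 1 to compound 2 (0.74 log units; beyond the scatter) bears on it only loosely, as it shows that a swap at this place can move the number by a modest amount. A change of similar or smaller size is therefore expected, with no firm direction, and the estimate starts from compound 2 at 8300 nM. The expected move is a 1.2-fold higher number from compound 2 to compound 3 (0.08 log units; within the scatter). For compound 3 the estimated value is 10000 nM, with an expected range from 3500 nM to 30000 nM.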

Compound 3, half-maximal inhibitory concentration: 2900 nM
Compound 3: the middle estimate sits 3.4-fold (0.54 log units) above what was measured, and the stated range ends above it.
By their numbers in this assay, from the lowest: compound 3; then compound 2; then compound 1.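

Moving the chlorine while keeping the same atoms, from 3-chlorophenyl to 2-chlorophenyl, gives a 2.9-fold lower number from compound 2 to compound 3 (0.46 log units; beyond the scatter) in this assay, so on this ring nitrogen the result depends on where the chlorine sits on the phenyl ring as well as on which group is attached. Compound 3 now has the lowest number of the three, and its step from the first compound is much larger, at a 16-fold lower number from compound 1 to compound 3 (1.20 log units; beyond the scatter), so changes at this one place alone span a large range of activity on these cells. Nothing available explains why these two chlorophenyl isomers differ.

With only 2-chlorophenyl, 3-chlorophenyl and 4-methoxyphenyl shown on this nitrogen, 4-chlorophenyl remains an open comparison that would complete the set of chlorine placements. Going by these compounds, it also remains open whether chlorine itself matters, which 2-fluorophenyl or 2-methoxyphenyl could test, and whether the phenyl ring needs to sit directly on the nitrogen, which a benzyl group could test.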